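The source may report more compounds than this note shows. Statements on the series, on what has been measured and on what is new or still open speak of the compounds shown alone.

Measured so far in an ADME assay on Vero cells (Chlorocebus sabaeus) for cytotoxicity, read by MTT assay, with a stated time of 96 h; a higher number here means that more compound is tolerated, a lower number that less compound is tolerated:

Compound 1, `C/C(=N\NC(N)=O)c1ccc2[nH]c(-c3ccccc3)nc2c1`; in this assay compound 1 gives > 100000 nM, which is a limit of the assay rather than a number.
Compound 2, `C/C(=N\NC(N)=O)c1ccc2[nH]c(-c3ccc(Cl)cc3)nc2c1`; in this assay compound 2 gives > 100000 nM, again a limit and not a number.
Within the data shown here, compound 3, `CC(=O)c1ccc2c(c1)nc(-c1ccccc1)n2C1CCCCC1`; in this assay compound 3 gives 80000 nM, the only plain number among the three.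

Compound 2 differs from compound 1 by chloro in place of hydrogen on an aromatic carbon. The step that the two limits leave unreadable from compound 1 to compound 2 cannot be read, because of the limit of > 100000 nM in this assay, at which 2 of the 3 values shown sit.

Compound 4, `CC(=O)c1ccc2c(c1)nc(-c1ccc(Cl)cc1)n2C1CCCCC1`, is not yet measured. It differs from compound 3 by chloro in place of hydrogen on an aromatic carbon, the same change as between compound 1 and compound 2. How the core of compound 3 differs from the core of compound 1 is not broken down here.

Since the earlier step is unreadable, the expectation for compound 4 rests mainly on compound 3 and its value 80000 nM. A step of roughly a 1.3-fold lower number from compound 3 to compound 4 (0.12 log units; within the scatter) is expected from compound 3 to compound 4. Compound 4 is therefore estimated at 60000 nM, likely between 20000 nM and 150000 nM.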

Compound 4, half-maximal cytotoxic concentration: > 100000 nM
Compound 4 was reported as a limit; the forecaster's own chance of this, stated with the estimate: 25%; at least 1.6-fold (0.22 log units) between middle value and limit.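

Compound 4 gives > 100000 nM in this assay, which is a limit of the assay and not a number. The chloro change therefore gives an at least 1.2-fold higher number from compound 3 to compound 4 (0.09 log units; that floor lies within the scatter), whose floor lies within the scatter, so this core shows no fall in the tolerated concentration but no certain rise either. Whether the change acts alike on both cores stays unanswered, because the step on the core of compound 1 cannot be read: the limit of > 100000 nM in this assay, at which 3 of the 4 values shown sit.

The compounds shown leave open how far the true values lie past the limit. They also leave open what an amine or a carboxylic acid would do in the place that chloro holds on the core of compound 3.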